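Swapping chloro for methoxy on the sulfonyl phenyl ring

A few compounds are considered here, and "the series" means these few. Any claim that something is new, unique, unknown or untested is made for them only; others in the source may bear on it.

Of the compounds shown here, three built on one shared core have been measured in a functional assay on CHO.K1 cells for antagonist activity at prostaglandin D2 receptor 2 (Homo sapiens), read by GTPgammaS binding, with a stated time of 1 h; on this read-out lower numbers stand for stronger inhibition and higher numbers for weaker inhibition. Compound 1 `Cc1c(Cc2cc(Br)ccc2S(=O)(=O)c2ccccc2)c2c(n1CC(=O)O)CCNC2=O` gives 3.9 nM. Compound 2 `Cc1c(Cc2ccccc2S(=O)(=O)c2ccccc2F)c2c(n1CC(=O)O)CCNC2=O` gives 3.6 nM, and compound 3 `Cc1c(Cc2ccccc2S(=O)(=O)c2cccc(Cl)c2)c2c(n1CC(=O)O)CCNC2=O` gives 4 nM. Compound 3 thus carries the highest of the three numbers, but its gaps to compound 1 and to compound 2 both lie within the usual scatter, so the three cannot be told apart in this assay. Among the measured compounds shown here, the one single-point change among them, a 1.1-fold higher number from compound 2 to compound 3 (0.05 log units; within the scatter), is likewise within the scatter.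

Compound 4 `COc1cccc(S(=O)(=O)c2ccccc2Cc2c3c(n(CC(=O)O)c2C)CCNC3=O)c1` has not yet been measured. It differs from compound 3 in one place: methoxy in place of chloro on an aromatic carbon. For the measured compounds named here, the only measured step that bears on this part of the molecule, a 1.1-fold higher number from compound 2 to compound 3 (0.05 log units; within the scatter), also altered a substituent on that same ring and stayed within the scatter. Going by the values given here, no measured compound carries a methoxy group, so this particular replacement is untested here. For compound 4 the expected step is a 1.1-fold higher number from compound 3 to compound 4 (0.05 log units; within the scatter), which means no change beyond the scatter. Compound 4 is estimated at 4.5 nM in this assay, with a range from 2 nM to 10 nM.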

Compound 4, half-maximal inhibitory concentration: 12 nM
Compound 4: the middle estimate sits 2.7-fold (0.43 log units) below what was measured, and the stated range ends below it.
By their numbers in this assay, from the lowest: compounds 2, 1 and 3 (each within the scatter of the next); then compound 4.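

In this assay the substituent on this ring does matter: the earlier change on the same ring stayed within the scatter, whereas methoxy in place of chloro gives a 3.0-fold higher number from compound 3 to compound 4 (0.48 log units; beyond the scatter) and so a modest weakening of inhibition. The wider change, 3-methoxyphenyl in place of 2-fluorophenyl on the sulfonyl sulfur, gives a 3.3-fold higher number from compound 2 to compound 4 (0.52 log units; beyond the scatter) and is also modest and beyond the scatter, so the methoxy compound stands apart from both halogen-bearing neighbours that differ from it in one place. Nothing available here says why a methoxy group on this aromatic carbon is tolerated less well than chloro.

The compounds shown do not settle whether the weakening is specific to methoxy, since a hydroxyl, a methyl, an amine or a longer chain such as ethoxy on the same carbon could fall near either compound 3 or compound 4. They also leave open whether methoxy elsewhere on this ring would give a similar step, or whether this step would recur with a bromo group on the other aromatic ring, as in compound 1.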